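Compound 3 to compound 4: a new substituent

The compounds below may be only part of what the source reports. "The series", "measured", "known", "first", "only" and "open" are said of these compounds alone.

Compound 1 `O=C(CCc1cccc2c1B(O)OC2)Nc1ccccc1` gives 230 nM
Compound 2 `COc1ccc(-c2cccc(NC(=O)CCc3cccc4c3B(O)OC4)c2)cc1` gives 88 nM
Compound 3 `O=C(CCc1cccc2c1B(O)OC2)Nc1cccc(-c2ccc(C(F)(F)F)cc2)c1` gives 510 nM

In a functional assay on MDA-MB-231 cells (Homo sapiens) for antiproliferative activity, read by MTT assay, with a stated time of 72 h (a lower number here means a stronger inhibitor, a higher number a weaker inhibitor), compound 3 gives 510 nM and is the weakest of the three measured compounds. The next structure is compound 4 `N#Cc1cccc(-c2cccc(NC(=O)CCc3cccc4c3B(O)OC4)c2)c1` and the change is 3-cyanophenyl in place of 4-(trifluoromethyl)phenyl on an aromatic carbon with 3-cyanophenyl in place of 4-(trifluoromethyl)phenyl on an aromatic carbon, meta to a large group.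

Among the measured compounds shown here, three measured steps bear on this change. With 4-methoxyphenyl in place of hydrogen the result was a 2.6-fold lower number from compound 1 to compound 2 (0.42 log units; beyond the scatter) and with 4-(trifluoromethyl)phenyl in place of hydrogen it was a 2.2-fold higher number from compound 1 to compound 3 (0.35 log units; beyond the scatter) while trifluoromethyl in place of methoxy gave a 5.8-fold higher number from compound 2 to compound 3 (0.76 log units; beyond the scatter) as well. All three are modest, and they run in both directions. For the measured compounds named here, no measured compound carries a nitrile, so the data offer only indirect guidance. Compound 3 holds the highest value at 510 nM and a modest move toward lower numbers is therefore expected. The expected step in this assay is a 2.6-fold lower number from compound 3 to compound 4 (0.41 log units; beyond the scatter) and it remains an uncertain one. Compound 4 is estimated at 200 nM with 80 nM to 500 nM as the expected range.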

Compound 4, half-maximal inhibitory concentration: 110 nM
Beside the measured number, compound 4's estimate is 1.8-fold (0.26 log units) above it; the range from low to high includes it.
By their numbers in this assay, from the lowest: compounds 2 and 4 (each within the scatter of the next); then compound 1; then compound 3.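

In this assay, the change from 4-(trifluoromethyl)phenyl to 3-cyanophenyl gives a 4.6-fold lower number from compound 3 to compound 4 (0.67 log units; beyond the scatter) and shows that the poorer result of compound 3 is not common to every substituted phenyl group on this aromatic carbon. Against the 4-methoxyphenyl group of compound 2, the 3-cyanophenyl group gives a 1.3-fold higher number from compound 2 to compound 4 (0.10 log units; within the scatter) and so does not separate the two, while against hydrogen it gives a 2.1-fold lower number from compound 1 to compound 4 (0.32 log units; beyond the scatter) and thus becomes the second group here to improve on the unsubstituted compound 1, with compound 3 the one case that goes against this. No measurement is available that would explain why these groups behave differently, so the result stands as an observation about these four compounds only.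

From compound 3 to compound 4 both the substituent and its place on the added phenyl ring change, so the compounds shown do not separate the effect of the nitrile from the effect of where it sits. As far as these compounds go, how an amine or a carboxylic acid on that ring would compare also remains open.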